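Swapping the carbonyl linker for a methylene in compound 2

This account rests on a few compounds, and the source may have more. Where it says the series, first, only, none or still open, it means among the compounds named here.

Of the compounds shown here, two sharing one core have so far been measured in an assay on isolated protein for inhibition of Discoidin domain-containing receptor 2 (Homo sapiens), read by ELISA, with a stated time of 60 min; on this read-out lower numbers stand for stronger inhibition and higher numbers for weaker inhibition. Compound 1 `Cc1ccc(C(=O)Nc2cccc(C(F)(F)F)c2)cc1-c1ccc2c(-c3ccc(N4CCN(C)CC4)cc3)n[nH]c2c1` gives 8.8 nM in this assay, and compound 2 `Cc1ccc(C(=O)Nc2cccc(C(F)(F)F)c2)cc1-c1ccc2c(-c3ccc(C(=O)N4CCN(C)CC4)cc3)n[nH]c2c1` gives 6.5 nM. Compound 2 thus holds the lower of the two numbers, but the step of a 1.4-fold lower number from compound 1 to compound 2 (0.13 log units; within the scatter) lies within the scatter, so the two compounds cannot be told apart on these data.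

Compound 3 `Cc1ccc(C(=O)Nc2cccc(C(F)(F)F)c2)cc1-c1ccc2c(-c3ccc(CN4CCN(C)CC4)cc3)n[nH]c2c1` has not yet been measured. It differs from compound 2 in one place: (4-methylpiperazin-1-yl)methyl in place of (4-methylpiperazin-1-yl)carbonyl on an aromatic carbon. Going by the values given here, the only measured step that bears on this change is a 1.4-fold lower number from compound 1 to compound 2 (0.13 log units; within the scatter), which also exchanged the group on the same aromatic carbon and stayed within the scatter. Because a 1.4-fold lower number from compound 1 to compound 2 (0.13 log units; within the scatter) was that small, the same kind of exchange in compound 3 is expected to give no step beyond the scatter in this assay, in either direction, so the expected step is a 1.1-fold higher number from compound 2 to compound 3 (0.03 log units; within the scatter). Compound 3 is therefore estimated at 7 nM in this assay, with a range from 3 nM to 18 nM.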

Compound 3, half-maximal inhibitory concentration: 6.2 nM
For compound 3 the middle estimate is 1.1-fold (0.05 log units) above the measured one, within the range that was stated.
By their numbers in this assay, from the lowest: compounds 3, 2 and 1 (each within the scatter of the next).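

In this assay, (4-methylpiperazin-1-yl)methyl in place of (4-methylpiperazin-1-yl)carbonyl gives a 1.0-fold lower number from compound 2 to compound 3 (0.02 log units; within the scatter), so on this aromatic carbon, para to a large group, the loss of the carbonyl leaves no readable mark on the number. Going by these compounds alone, the same group in place of 4-methylpiperazin-1-yl gives a 1.4-fold lower number from compound 1 to compound 3 (0.15 log units; within the scatter), so the direct attachment, the carbonyl and the methylene now form a set of three that this assay cannot separate, where the earlier pair offered only a single comparison. Nothing measured here on these compounds offers an explanation for this flat result.

All three compounds keep the 4-methylpiperazine ring, so they leave open whether the number depends on that ring at all, for instance whether a morpholine, a dimethylamino group or a carboxylic acid at the same place would stay within the scatter. They also leave open whether the flat result extends to a longer chain, such as an ethylene link between the aromatic carbon and the piperazine.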